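This account rests on a few compounds, and the source may have more. Where it says the series, first, only, none or still open, it means among the compounds named here.

Working notes on the series. Three compounds have numbers in an assay on isolated protein for inhibition of Calpain-1 catalytic subunit (Sus scrofa), read by FRET (a lower number here means a stronger inhibitor, a higher number a weaker inhibitor), so far. Compound 1 `O=C(O)/C(S)=C/c1cccc(F)c1` gives 19000 nM in this assay, the highest of the three numbers; compound 2 `O=C(O)/C(S)=C/c1c[nH]c2ccc(I)cc12` gives 100 nM and compound 3 `O=C(O)/C(S)=C/c1c[nH]c2c(I)cccc12` gives 90 nM, both far below compound 1 and beyond the scatter, but on a different core, so neither pair with compound 1 is a single-change step. Compound 4 `O=C(O)/C(S)=C/c1cccc(I)c1` keeps the core of compound 1 and differs from it by iodo in place of fluoro on an aromatic carbon. Going by the values given here, no step between measured compounds tells what this halogen swap alone does. A modest move towards a lower number is expected, a 3.2-fold lower number from compound 1 to compound 4 (0.50 log units; beyond the scatter), with wide uncertainty. For compound 4 the estimate in this assay is 6000 nM, within 1500 nM to 20000 nM.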

Compound 4, half-maximal inhibitory concentration: 4300 nM
The estimate for compound 4 lay 1.4-fold (0.14 log units) above the measured number; low and high end bracket the measured number.
By their numbers in this assay, from the lowest: compounds 3 and 2 (each within the scatter of the next); then compound 4; then compound 1.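

Iodo in place of fluoro on an aromatic carbon of the shared core gives a 4.4-fold lower number from compound 1 to compound 4 (0.65 log units; beyond the scatter) in this assay, so this position responds to the identity of the halogen. This single swap is the only direct read on that position, and one pair sets no trend. No evidence at hand explains the change.

Open, from the compounds shown here alone, is how a hydrogen, a chloro, a methoxy, an amine or a carboxylic acid at this place would compare with iodo on the same core. Also open, going by these compounds, is whether fluoro in place of iodo on the core of compound 2 would move the number the same way.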